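From methoxy to ethoxy on a shared core

The source may report more compounds than this note shows. Statements on the series, on what has been measured and on what is new or still open speak of the compounds shown alone.

Compounds measured so far in a physicochemical assay for lipophilicity, at pH 7.4 (on this read-out lower numbers stand for lower lipophilicity and higher numbers for higher lipophilicity), are two:

Compound 1 `COc1cccc(C(=O)NCc2c(C)cc(C)[nH]c2=O)c1Cl` gives 1.2
Compound 2 `COc1cccc(C(=O)NCc2c(C)cc(C)[nH]c2=O)c1C` gives 1.5

Compound 2, at 1.5, stands within the scatter of compound 1, at 1.2, so the two cannot be told apart on these numbers. Within the data shown here, the one measured step is a number 0.30 log units higher from compound 1 to compound 2 (within the scatter) and it comes from methyl in place of chloro on an aromatic carbon.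

Compound 3 `CCOc1cccc(C(=O)NCc2c(C)cc(C)[nH]c2=O)c1C` differs from compound 2 by a single change, (methyl in place of hydrogen on a saturated chain carbon bound to an oxygen on an aromatic ring), which is methyl in place of hydrogen on a saturated chain carbon bound to an oxygen on an aromatic ring, or methoxy to ethoxy. Among the measured compounds shown here, no measured pair shows this change, so the step to compound 2, a number 0.30 log units higher from compound 1 to compound 2 (within the scatter), bears on it only loosely, as a guide to size. In this assay the expected move is upward and modest, and it may only just clear the scatter. The estimated step is a number 0.40 log units higher from compound 2 to compound 3 (beyond the scatter) in that direction. The estimate for compound 3 is 1.9, expected to fall from 1.6 to 2.2 on this read-out.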

Compound 3, distribution coefficient: 2.1
Compound 3: middle estimate off by 0.20 log units, on the low side; the range from low to high includes it.
By their numbers in this assay, from the lowest: compounds 1 and 2 (each within the scatter of the next); then compound 3.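

In this assay, among these compounds, the change of methoxy to ethoxy gives a number 0.60 log units higher from compound 2 to compound 3 (beyond the scatter) and so supplies the first step on this shared core that lies beyond the scatter. The earlier exchange, a number 0.30 log units higher from compound 1 to compound 2 (within the scatter), left its two compounds indistinguishable, whereas a single added methyl on the saturated chain carbon bound to an oxygen on an aromatic ring separates compound 3 clearly from compound 2, showing that the read-out can respond to a change at this position. Nothing available explains the size or direction of this step.

Going by these compounds, whether a propyl ether or a still longer chain at this oxygen would carry the read-out further remains open, as does whether methoxy to ethoxy would give a similar step with chloro in place of the aromatic methyl. The compounds shown also do not tell how an amine or a carboxylic acid at the end of that chain would read in this assay, so this single step cannot yet be taken as a trend.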